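Ethylsulfanyl Enters the Core of Compound 3

This account rests on a few compounds, and the source may have more. Where it says the series, first, only, none or still open, it means among the compounds named here.

Of the compounds shown here, three have been tested in a functional assay on the whole organism for antagonist activity, with Mus musculus as the target (a higher number here means that more compound is needed for the effect, a lower number that less compound is needed), and none of them gives a number. Compound 1 (`CSc1n[nH]c(-c2ccc(F)cc2)n1`) reads > 200 mg/kg, which is a limit of the assay. Compound 2 (`Cn1c(-c2cccs2)nnc1[S+](C)[O-]`) reads > 200 mg/kg, also a limit. Compound 3 (`Cn1c(-c2ccccc2)nnc1[S+](C)[O-]`) stands at > 100 mg/kg, and this too is only a limit.

Compound 4 (`CCSc1nnc(-c2ccccc2)n1C`) differs from compound 3 in one place: a group of 3 heavy atoms (2 carbon, 1 sulfur; no ring) in place of a group of 3 heavy atoms (1 carbon, 1 oxygen, 1 sulfur; no ring), on an aromatic carbon. Ethylsulfanyl stands in place of a group of 3 heavy atoms, on an aromatic carbon of a five-membered aromatic ring with 3 nitrogen.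

For the measured compounds named here, with limits alone, no measured step exists to give a size for this change in this assay. The direction is therefore a judgement, and it points toward less compound being needed. The expected change is an at least 1.6-fold lower number from compound 3 to compound 4 (0.22 log units; that floor lies within the scatter), a modest one held with wide uncertainty. For compound 4 the estimated dose is 60 mg/kg, with an expected range from 20 mg/kg to 200 mg/kg.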

Compound 4, dose for half-maximal effect: > 200 mg/kg
Compound 4 ended at the assay's limit; the forecaster's own chance of this, stated with the estimate: 30%; middle value at least 3.3-fold (0.52 log units) from the limit.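

Compound 3 and compound 4 both read only as limits in this assay, and the step between them cannot be read. The compounds shown leave open what dose any of the four would need, and whether ethylsulfanyl changes that dose at all.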